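Swapping hydroxymethyl for carboxy in compound 2

The source may report more compounds than this note shows. Statements on the series, on what has been measured and on what is new or still open speak of the compounds shown alone.

- compound 1 `CC(C)=CCC[C@H](C)c1ccc(C)c(CNCCO)c1O`: 14400 nM
- compound 2 `CC(C)=CCC[C@H](C)c1ccc(C)c(CNCCCCCO)c1O`: 10700 nM

For the measured compounds named here, in a functional assay on MDA-MB-231 cells (Homo sapiens) for inhibition, read by MTT assay, with a stated time of 72 h (a lower number here means a stronger inhibitor, a higher number a weaker inhibitor), compound 2 gives 10700 nM, level with the only other compound measured so far. Going by the values given here, the one measured step is a 1.3-fold lower number from compound 1 to compound 2 (0.13 log units; within the scatter). Among the compounds with values here, that step changed the chain while keeping its hydroxy group, and no measured compound carries a carboxy, so the data give no direct guide to the next change.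

The next compound is compound 3 `CC(C)=CCC[C@H](C)c1ccc(C)c(CNCCCCC(=O)O)c1O`. Its change is carboxy in place of hydroxymethyl on a saturated chain carbon, four bonds along the chain from an amine nitrogen, on a saturated chain carbon, four bonds along the chain from an amine nitrogen. With so little to go on, only a modest shift towards a higher number is expected in this assay, and no step beyond the scatter can be firmly predicted. The estimated step is a 1.5-fold higher number from compound 2 to compound 3 (0.17 log units; within the scatter). For compound 3 the expected value is 16000 nM, with an estimated range of 7000 nM to 40000 nM.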

Compound 3, half-maximal inhibitory concentration: > 50000 nM
Compound 3 ended at the assay's limit (the forecaster's own chance of this, stated with the estimate: 15%); middle value at least 3.1-fold (0.49 log units) away from the limit.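

Compound 3 reads as a limit, not a number, in this assay: the limit of > 50000 nM in this assay, at which 1 of the 3 values shown sits.

For the compounds shown here, this position proves sensitive to what sits at the end of the chain, which the earlier compounds did not show: the change that kept a hydroxy group gave a 1.3-fold lower number from compound 1 to compound 2 (0.13 log units; within the scatter), while swapping hydroxymethyl for carboxy gives an at least 4.6-fold higher number from compound 2 to compound 3 (0.66 log units; beyond the scatter). The comparison with the other hydroxy compound points the same way, with an at least 3.4-fold higher number from compound 1 to compound 3 (0.54 log units; beyond the scatter), so among these three compounds a step beyond the scatter appears only with the carboxy.

On these data alone, the full size of both new steps stays open, as each gives only a lower bound. A methyl ester or an amide at the same chain end, or a carboxylic acid on a shorter or longer chain, would show whether the change depends on the acid itself or on where it sits.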